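The compounds below may be only part of what the source reports. "The series", "measured", "known", "first", "only" and "open" are said of these compounds alone.

The measured compounds and their values:

Compound 1 `O=C(Nc1cc(C(F)(F)F)cc(C(F)(F)F)c1)c1ccccc1O`: in an assay on cells for antagonist activity at P2X purinoceptor 4 (Homo sapiens), read by fluorescence and calcium flux, with a stated time of 30 min (on this read-out higher numbers stand for weaker inhibition and lower numbers for stronger inhibition), compound 1 gives 155 nM.
Compound 2 `O=C(Nc1cc(C(F)(F)F)cc(C(F)(F)F)c1)c1ccc(Cl)cc1O`: compound 2 gives 209 nM.
Compound 3 `O=C(Nc1cc(Cl)cc(Cl)c1)c1cc(Cl)ccc1O`: compound 3 gives 712 nM.

Compound 4 `O=C(Nc1cccc(Cl)c1)c1cc(Cl)ccc1O` has not been measured. It differs from compound 3 by hydrogen in place of chloro on an aromatic carbon. The same kind of change, though not the same one, separates compound 2 from compound 1, namely (hydrogen in place of chloro on an aromatic carbon), and that step gave a 1.3-fold lower number from compound 2 to compound 1 (0.13 log units; within the scatter). The surroundings differ: in compounds 2 and 1 the chloro sits meta to a hydroxy group and para to a large group, while in compounds 3 and 4 it sits meta to a chloro group and meta to a large group. How the cores of compound 2 and compound 3 differ is not broken down here; what their values show is that compound 3 gives the higher number. For compound 4 the step from compound 3 is expected to be about a 1.3-fold higher number from compound 3 to compound 4 (0.13 log units; within the scatter) in this assay, resting on the small step of a 1.3-fold lower number from compound 2 to compound 1 (0.13 log units; within the scatter), with some room for a weaker result. Compound 4 is thus expected to give roughly 950 nM, between 350 nM and 2600 nM.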

Compound 4, half-maximal inhibitory concentration: 135 nM
Beside the measured number, compound 4's estimate is 7.0-fold (0.85 log units) above it, outside the stated range (below it).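

In this assay, swapping a chloro group for hydrogen did not have the same effect on every core, and here it gave a 5.3-fold lower number from compound 3 to compound 4 (0.72 log units; beyond the scatter). Set beside the earlier case of the same swap, the two steps clearly differ: the same change on two cores in this assay, a 1.3-fold lower number (0.13 log units; within the scatter) from compound 2 to compound 1 and a 5.3-fold lower number (0.72 log units; beyond the scatter) from compound 3 to compound 4, 3.9-fold (0.59 log units) apart, beyond the scatter of two such steps

So in this series, a step measured on one core is not a reliable guide to the same change on another; it does not show which feature of the cores accounts for the gap, and two pairs are too few to yield a rule for where the swap helps.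

The compounds shown leave open how the swap would behave on further cores, and whether a group other than chloro, such as a methoxy group, an amine or a carboxylic acid, would fare better at that aromatic carbon. Also open, from the compounds shown here alone, is what happens when the hydroxy group, present in all four compounds, is replaced.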